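The source may hold more compounds than are shown below. What is called first, only, known or untested is meant among the compounds shown, and "the series" means these compounds.

Measured compounds:
Compound 1, `Nc1scc(CN2CCN(c3cc(Cl)cc(Cl)c3)CC2)c1C(=O)c1ccc(Cl)cc1`, gives -74%.
Compound 2, `Nc1scc(CN2CCN(c3ccc([N+](=O)[O-])cc3)CC2)c1C(=O)c1ccc(Cl)cc1`, gives -17%.
Compound 3, `Nc1scc(CN2CCN(c3ccccc3C(F)(F)F)CC2)c1C(=O)c1ccc(Cl)cc1`, gives -60%.

In a functional assay on CHO cells with adenosine receptor A1 (Homo sapiens) as the target, read by cAMP accumulation and immunoassay, with a stated time of 6 min, tested at 10 uM (a higher number here means a weaker effect of the compound at the concentration tested, a lower number a stronger effect), compound 3 holds the second highest of the three numbers. Its nearest neighbour is compound 1, with a step of a number 14 percentage points higher from compound 1 to compound 3 (beyond the scatter); its furthest is compound 2, with a step of a number 43 percentage points lower from compound 2 to compound 3 (beyond the scatter). Compound 4, `Nc1scc(CN2CCN(c3ccc(Cl)c(C(F)(F)F)c3)CC2)c1C(=O)c1ccc(Cl)cc1`, has not yet been measured. It differs from compound 3 by 4-chloro-3-(trifluoromethyl)phenyl in place of 2-(trifluoromethyl)phenyl on an amine nitrogen in a ring. All three measured steps exchange the aryl group on this same ring nitrogen, so all bear on the change. The exchange toward 4-nitrophenyl gave a number 57 percentage points higher from compound 1 to compound 2 (beyond the scatter), a large move; the exchanges among chloro- and trifluoromethyl-bearing phenyl groups gave the modest a number 14 percentage points higher from compound 1 to compound 3 (beyond the scatter) and the large reversal a number 43 percentage points lower from compound 2 to compound 3 (beyond the scatter). The incoming 4-chloro-3-(trifluoromethyl)phenyl carries chlorine and trifluoromethyl, like the groups of compounds 1 and 3 rather than the nitro of compound 2, so compound 4 is expected to fall between compound 1 and compound 3, with an expected step of a number 10 percentage points lower from compound 3 to compound 4 (within the scatter). Compound 4 is therefore estimated at -70%, within -90% to -45%.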

Compound 4, a percentage reported as activity, at one concentration (the size of the read-out at that concentration, not a potency): -60%
Compound 4: the middle estimate sits 10 percentage points below what was measured; the range from low to high includes it.
By their numbers in this assay, from the lowest: compound 1; then compounds 3 and 4 (each within the scatter of the next); then compound 2.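

In this assay, the 4-chloro-3-(trifluoromethyl)phenyl and 2-(trifluoromethyl)phenyl groups on this ring nitrogen cannot be told apart (no change at the digits printed from compound 3 to compound 4 (within the scatter)), although the entering group carries one more chlorine. Compound 4 stands apart from the compounds with the other two aryl groups, both from the 4-nitrophenyl compound (a number 43 percentage points lower from compound 2 to compound 4 (beyond the scatter)) and from the 3,5-dichlorophenyl compound (a number 14 percentage points higher from compound 1 to compound 4 (beyond the scatter)), so the two trifluoromethyl-bearing compounds share the same printed steps to both. No measurement given here accounts for these steps.

The compounds shown leave open whether a cyclohexyl or methyl group on this ring nitrogen, or a phenyl group bearing an amine or a carboxylic acid, would fit this pattern. They also leave open whether these steps would persist with a group other than 4-chlorophenyl on the carbonyl of the shared core.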